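The source may hold more compounds than are shown below. What is called first, only, known or untested is meant among the compounds shown, and "the series" means these compounds.

Compound 1 `COc1ccc(CN(C)CCCn2c(=O)oc3ccccc32)cc1`: 83 nM
Compound 2 `O=C(NCc1ccccc1)C1CCN(Cc2ccccc2)CC1`: 22.5 nM
Compound 3 `Cc1ccc(CN2CCC(Cn3c(=O)oc4ccccc43)CC2)cc1`: 3.07 nM

In an assay on membranes from liver for displacement of a labelled ligand from Sigma non-opioid intracellular receptor 1 (Rattus norvegicus), read by scintillation counting (on this read-out lower numbers stand for stronger inhibition and higher numbers for weaker inhibition), compound 1 gives the highest of the three numbers. Compound 2 lies well below it, and compound 3 lower still; both gaps are beyond the usual scatter. Compound 4 `Cc1ccc(CN(C)CCCn2c(=O)oc3ccccc32)c(C)c1` keeps the core of compound 1 and changes one group: 2,4-dimethylphenyl in place of 4-methoxyphenyl on a saturated chain carbon bound to an amine nitrogen. For the measured compounds named here, no measured pair shows this exact change, so its size is open. Both the leaving and the entering group are single six-membered carbon rings, and on that basis only a small shift is expected, most likely toward a somewhat lower number. The expected step of a 1.7-fold lower number from compound 1 to compound 4 (0.22 log units; within the scatter) should stay close to the scatter. Compound 4 is estimated at 50 nM, within 15 nM to 160 nM.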

Compound 4, inhibition constant: 1830 nM
For compound 4 the middle estimate is 37-fold (1.56 log units) below the measured one, and the stated range ends below it.
By their numbers in this assay, from the lowest: compound 3; then compound 2; then compound 1; then compound 4.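

In this assay, putting 2,4-dimethylphenyl in place of 4-methoxyphenyl on a saturated chain carbon bound to an amine nitrogen gives a 22-fold higher number from compound 1 to compound 4 (1.34 log units; beyond the scatter) and so shows that this position is far from indifferent to the group it carries. Both groups hold a single six-membered aromatic ring of carbon only and the same count of heavy atoms, so those shared counts do not settle the outcome. No measurement here explains this step. The compounds shown leave open whether losing the methoxy group or gaining the methyl groups matters more. A 2-methylphenyl group at the same place would help separate the two.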